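The compounds below may be only part of what the source reports. "The series", "measured", "known", "first", "only" and "open" are said of these compounds alone.

Measured so far:
- compound 1, `O=C1CSc2ccccc2N1Cc1cn(-c2ccc([N+](=O)[O-])cc2)nn1`: 13.3%
- compound 2, `O=C1CSc2ccccc2N1Cc1cn(Cc2cccc([N+](=O)[O-])c2)nn1`: 0%

Both compounds were tested in an ADME assay on HeLa cells (Homo sapiens) for antiproliferative activity, read by MTT assay, with a stated time of 72 h, tested at 3 ug/mL; on this read-out lower numbers stand for a weaker effect and higher numbers for a stronger effect at the one concentration tested. Compound 2 gives 0%, the lowest of the two numbers shown. Its nearest neighbour is compound 1, which gives 13.3%, a gap that lies beyond the usual scatter of this assay. Among the measured compounds shown here, no step between two measured compounds that differ in only one place is available, so the effect of moving a nitro group around a ring has not yet been seen.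

Compound 3, `O=C1CSc2ccccc2N1Cc1cn(Cc2ccc([N+](=O)[O-])cc2)nn1`, is built from compound 2 by one change: 4-nitrophenyl in place of 3-nitrophenyl on a saturated chain carbon bound to an aromatic nitrogen. With nothing measured on such a move, the expectation for this assay is a small step from compound 2 to compound 3, a number 5 percentage points higher from compound 2 to compound 3 (within the scatter), not beyond the scatter. Compound 3 is therefore estimated at 5%, within a range of 0% to 20%.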

Compound 3, a percentage reported as activity, at one concentration (the size of the read-out at that concentration, not a potency) in the HeLa assay: 36.5%
Compound 3: middle estimate off by 31.5 percentage points, on the low side, outside the stated range (above it).
By their numbers in the HeLa assay, from the lowest: compound 2; then compound 1; then compound 3.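

Swapping 3-nitrophenyl for 4-nitrophenyl on a saturated chain carbon bound to an aromatic nitrogen keeps the same atoms and joins them differently, yet in the HeLa assay compound 2 gives 0% and compound 3 gives 36.5%, which is a number 36.5 percentage points higher from compound 2 to compound 3 (beyond the scatter), so at this place the arrangement of the nitrophenyl group matters to the read-out. In a physicochemical assay, read by spectrophotometry (on this read-out higher numbers stand for weaker inhibition and lower numbers for stronger inhibition), compound 2 gives 34.1 ug/mL and compound 3 gives 27.4 ug/mL, which is a 1.2-fold lower number from compound 2 to compound 3 (0.10 log units; within the scatter), so this pair separates clearly on one read-out but not on the other. Nothing available explains the gap between these two compounds.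

The compounds shown leave open whether an amine or a carboxylic acid in place of the nitro group would keep the higher read-out of 4-nitrophenyl. From the compounds shown here alone, they also rest on a single pair, so whether a longer chain or another core would show the same step remains unknown.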